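The source may hold more compounds than are shown below. What is called first, only, known or untested is meant among the compounds shown, and "the series" means these compounds.

In an ADME assay on microsomes from liver (Mus musculus) for metabolic stability, read by LC-MS, using NADPH, with a stated time of 10 min, tested at 0.1 uM (a lower number here means slower removal, a higher number faster removal of the compound), compound 1 (`CC1SC(c2cccc(C(=O)NCCCCc3ccccc3)c2)N(c2ccc(C3CC3)cc2)C1=O`) gives 3210 mL.min-1.g-1 and compound 3 (`O=C(NCCCCc1ccccc1)c1cccc(C2SCC(=O)N2c2ccc(C3CC3)cc2)c1`) gives 2960 mL.min-1.g-1. For the measured compounds named here, the single measured step between compounds that differ in one place, a 1.1-fold lower number from compound 1 to compound 3 (0.04 log units; within the scatter), is hydrogen in place of methyl on a saturated ring carbon, and it leaves these two level. Compound 2 (`Cc1ccnc(N2C(=O)CSC2c2cccc(C(=O)NCCCCn3cccn3)c2)c1`) gives 392 mL.min-1.g-1, well under both, so compound 1 stands at the fast-clearing end of the three measured compounds, level with compound 3.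

Compound 4 (`COc1ccccc1N1C(=O)C(C)SC1c1cccc(C(=O)NCCCCc2ccccc2)c1`) keeps the rest of compound 1 and changes one group: 2-methoxyphenyl in place of 4-cyclopropylphenyl on an amide-type nitrogen in a ring. That is 2-methoxyphenyl in place of 4-cyclopropylphenyl on an amide-type nitrogen in a ring. The measured step does not touch this place, so it gives no direct size for the change. Compound 2, at 392 mL.min-1.g-1, lacks 4-cyclopropylphenyl but also differs from compound 1 elsewhere, so it offers only a loose hint that a lower number is possible. A moderate move towards slower removal is therefore expected, with wide uncertainty. The estimated size is a 1.9-fold lower number from compound 1 to compound 4 (0.28 log units; within the scatter). Compound 4 is expected at 1700 mL.min-1.g-1, with an estimated range from 700 mL.min-1.g-1 to 3500 mL.min-1.g-1.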

Compound 4, intrinsic clearance in microsomes: 2950 mL.min-1.g-1
Compound 4: middle estimate off by 1.7-fold (0.24 log units), on the low side; the measured number falls inside the stated range.
By their numbers in this assay, from the lowest: compound 2; then compounds 4, 3 and 1 (each within the scatter of the next).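

For the compounds shown here, the exchange of 4-cyclopropylphenyl for 2-methoxyphenyl on the amide-type nitrogen in a ring is the only measured step at this place, and in this assay it reads a 1.1-fold lower number from compound 1 to compound 4 (0.04 log units; within the scatter). With the rest of compound 1 kept, a group with a three-membered ring leaves and a group with a hydrogen-bond acceptor enters, yet the two compounds stay level, so losing 4-cyclopropylphenyl alone does not reproduce the low number of compound 2, 392 mL.min-1.g-1. Nothing measured here speaks to why this exchange leaves the number level.

The compounds shown leave open which of the places where compound 2 differs from compound 1 goes with its lower number, the group on that nitrogen or the far end of its side chain, as no single-place step separates them. Also open, from the compounds shown here alone, is whether a carboxylic acid or an amine in place of 2-methoxyphenyl on the amide-type nitrogen in a ring would move the number beyond the scatter.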